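Swapping the Basic Amine Tail of a Vasopressin Antagonist

A few compounds are considered here, and "the series" means these few. Any claim that something is new, unique, unknown or untested is made for them only; others in the source may bear on it.

Measured compounds:
compound 1 `O=C(Nc1ccc(C(=O)N2CCCCc3sccc32)cc1OCCCC(=O)N1CCC(N2CCCCC2)CC1)c1ccccc1-c1ccccc1`, 20 nM
compound 2 `COc1cc(C(=O)N2CCCC(N(C)C)c3sccc32)ccc1NC(=O)c1ccccc1-c1ccccc1`, 10 nM
compound 3 `O=C(Nc1ccc(C(=O)N2CCCN(CCN3CCCC3)c3sccc32)cc1)c1ccccc1-c1ccccc1`, 10 nM

In an assay on adrenal medulla for inhibition of Vasopressin V2 receptor (Rattus norvegicus), read by radioligand binding (a higher number here means a weaker inhibitor, a lower number a stronger inhibitor), compound 1 gives the highest of the three numbers, yet compound 2 and compound 3 each lie within the usual scatter of it, so the three cannot be ranked. Compound 4 `CN1CCCN(C(=O)CCCOc2cc(C(=O)N3CCCCc4sccc43)ccc2NC(=O)c2ccccc2-c2ccccc2)CC1` has not been measured. It differs from compound 1 in one place: 4-methyl-1,4-diazepan-1-yl in place of 4-(piperidin-1-yl)piperidin-1-yl on a carbonyl carbon. Both groups carry a single hydrogen-bond acceptor and no charge, and the change sits on the amide far from the shared core. The step from compound 1 to compound 4 is expected to be small, without a clear direction beyond the scatter: a 1.3-fold higher number from compound 1 to compound 4 (0.10 log units; within the scatter). Compound 4 is therefore estimated at 25 nM, with a range from 8 nM to 80 nM.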

Compound 4, half-maximal inhibitory concentration: 3 nM
Beside the measured number, compound 4's estimate is 8.3-fold (0.92 log units) above it, outside the stated range (below it).
By their numbers in this assay, from the lowest: compound 4; then compounds 2, 3 and 1 (each within the scatter of the next).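

In this assay the group on this carbonyl carbon proves able to shift the number: 4-methyl-1,4-diazepan-1-yl in place of 4-(piperidin-1-yl)piperidin-1-yl gives a 6.7-fold lower number from compound 1 to compound 4 (0.82 log units; beyond the scatter) and thus a change beyond the scatter. Going by these compounds alone, the earlier compounds offered no single-place step, so this is the first change that can be read on its own. Nothing available here shows why the number falls. Open, as far as these compounds go, is how a 4-methylpiperazin-1-yl or a 1,4-diazepan-1-yl without its methyl would behave on this same carbonyl carbon.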